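Swapping the amide substituent on a weak kinase inhibitor

This account rests on a few compounds, and the source may have more. Where it says the series, first, only, none or still open, it means among the compounds named here.

Compound 1 `CCCNC(=O)c1cccc(C#Cc2ccccc2Nc2ncnc3ccc(Cl)nc23)c1` gives 3900 nM.
Compound 2 `CNC(=O)c1oc2ccc(Nc3ncnc4ccc(Cl)nc34)cc2c1C` gives 2500 nM.

Both numbers come from an assay on isolated protein for inhibition of MAP kinase-interacting serine/threonine-protein kinase 2 (Homo sapiens), read by HTRF, in the presence of a further agent that is not named here; a lower number here means a stronger inhibitor, a higher number a weaker inhibitor. For the measured compounds named here, compound 1 has the higher of the two numbers, but compound 2, its only neighbour, sits within the usual scatter of repeated measurements, so the two cannot be told apart on potency. Both are weak inhibitors.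

Compound 3 `CN(C)C(=O)c1cccc(C#Cc2ccccc2Nc2ncnc3ccc(Cl)nc23)c1` has not yet been measured. It differs from compound 1 in a single place: dimethylamino in place of propylamino on a carbonyl carbon. Going by the values given here, no measured pair in this set shows the effect of that change, so the expectation rests on the change alone, together with the weak starting point of compound 1. The step from compound 1 to compound 3 in this assay is expected to be small, a 1.3-fold higher number from compound 1 to compound 3 (0.11 log units; within the scatter), leaning if anything toward a weaker inhibitor. Compound 3 is therefore expected to give 5000 nM, within a range from 1500 nM to 15000 nM.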

Compound 3, half-maximal inhibitory concentration: > 10000 nM
Compound 3: only a limit was reported; the forecaster's own chance of this, stated with the estimate: 10%; at least 2.0-fold (0.30 log units) between middle value and limit.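

On the core of compound 1, the group on this carbonyl carbon clearly matters: dimethylamino in place of propylamino gives an at least 2.5-fold higher number from compound 1 to compound 3 (0.40 log units; beyond the scatter) in this assay, and this step lies beyond the scatter. Compound 3 is reported only as a limit, not as a number: the limit of > 10000 nM in this assay, at which 1 of the 3 values shown sits.

The change swaps a group that carries a hydrogen-bond donor for one that carries none, and it also alters the chain, so this single pair cannot show which of these differences counts.

The compounds shown leave open how an ethylamino or a butylamino group on this same carbonyl carbon would read, and such groups would help separate the role of the amide hydrogen from that of chain length. As far as these compounds go, how far compound 3 lies past its limit also stays open.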